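Series notes: hydrazine carbamoyl extension in the shared core

A few compounds are considered here, and "the series" means these few. Any claim that something is new, unique, unknown or untested is made for them only; others in the source may bear on it.

Measured compounds:
- compound 1, `O=C(NC(c1ccccc1)c1ccc(Cl)cc1)n1nnc2ccccc21`: 63%
- compound 2, `COc1cc(NC(C)CCCNC(=O)NN)c2ncccc2c1`: 70%
- compound 3, `CCOC(=O)N(C)C(c1ccccc1)c1ccccc1`: "not active" (no number reported)

In a physicochemical assay for inhibition, read by spectrophotometry, tested at 100 uM (a higher number here means more inhibition at the concentration tested (going by the name of the read-out), a lower number less inhibition), compound 2 gives 70%. Of the two numbers recorded, this is the highest, though compound 1 at 63% lies within the usual scatter of it, so no order between compound 1 and compound 2 can be read from these two values. Compound 3 is recorded as not active, without a number.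

Compound 4, `COc1cc(NC(C)CCCNC(=O)NNC(=O)NC(CO)(CO)CO)c2ncccc2c1`, has not been measured. It differs from compound 2 in a single place: (2-hydroxy-1,1-bis(hydroxymethyl)ethyl)carbamoyl in place of hydrogen on an amine nitrogen.

Among the compounds with values here, no step between measured compounds is available to calibrate this change, and the two compounds with numbers share no close structural relation. The expectation rests only on compound 2 and the nature of the change, so the step from compound 2 to compound 4 in this assay is expected to be small, a number 5 percentage points lower from compound 2 to compound 4 (within the scatter), and not beyond the scatter in either direction. For compound 4 the estimated read-out in this assay is 65%, with a range from 40% to 88%.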

Compound 4, a percentage reported as inhibition, at one concentration (the size of the read-out at that concentration, not a potency): 49%
The estimate for compound 4 lay 16 percentage points above the measured number; low and high end bracket the measured number.
By their numbers in this assay, from the lowest: compound 4; then compounds 1 and 2 (each within the scatter of the next).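

In this assay, within the data shown here, (2-hydroxy-1,1-bis(hydroxymethyl)ethyl)carbamoyl in place of hydrogen on an amine nitrogen gives a number 21 percentage points lower from compound 2 to compound 4 (beyond the scatter), the first step that can be read. What sits on the amine nitrogen whose other neighbour is an amide-type nitrogen therefore changes the read-out in this assay, yet with all 10 heavy atoms of the new group in place, compound 4 still gives 49%. No measurement at hand accounts for the drop, and a single step cannot separate the contribution of the carbamoyl from that of the three hydroxymethyl arms.

Among the compounds shown, nothing tells whether a plain acetyl or an unsubstituted carbamoyl on the same nitrogen would stay within the scatter of compound 2 at 70% or would already bring the lower read-out. Equally open, on these data alone, is how a carboxylic acid, a dimethylamino group or a longer alkyl chain at this nitrogen would read, so no trend with the size or type of the group can yet be drawn.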